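The source may hold more compounds than are shown below. What is called first, only, known or untested is meant among the compounds shown, and "the series" means these compounds.

Compound 1 `COc1ccc(N(C)c2ccnc(Cl)n2)cc1F` gives 651 nM in a functional assay on A549 cells (Homo sapiens) for antiproliferative activity, read by MTT assay, with a stated time of 48 h; a higher number here means a weaker inhibitor, a lower number a stronger inhibitor. Compound 2 `COc1ccc(N(C)c2ccnc(Cl)n2)cc1Cl` carries chloro in place of fluoro on an aromatic carbon, and in this assay compound 2 gives 621 nM; the step is a 1.0-fold lower number from compound 1 to compound 2 (0.02 log units; within the scatter). Compound 3 `COc1ccc(N(C)c2cc(C)nc(C)n2)cc1F` rests on a different core; the difference between the two cores is not broken down here. In this assay compound 3 gives 632 nM, which the three measured values all sit close to. Compound 4 `COc1ccc(N(C)c2cc(C)nc(C)n2)cc1Cl` is still to be measured and differs from compound 3 by chloro in place of fluoro on an aromatic carbon. This is the same kind of change as that from compound 1 to compound 2, although the place is described once as meta to a group of 9 heavy atoms and once as meta to a large group. Because a 1.0-fold lower number from compound 1 to compound 2 (0.02 log units; within the scatter) lies within the scatter, the expected step is a 1.0-fold lower number from compound 3 to compound 4 (0.01 log units; within the scatter). For compound 4 in this assay the estimate is 620 nM, expected between 350 nM and 1100 nM.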

Compound 4, half-maximal inhibitory concentration: 780 nM
The estimate for compound 4 lay 1.3-fold (0.10 log units) below the measured number; the measured number falls inside the stated range.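

Chloro in place of fluoro gives a 1.2-fold higher number from compound 3 to compound 4 (0.09 log units; within the scatter) in this assay and so leaves the number within the scatter on this core, as it does on the core of compound 1. The two steps show no difference between the cores: the same change on two cores in this assay, a 1.0-fold lower number (0.02 log units; within the scatter) from compound 1 to compound 2 and a 1.2-fold higher number (0.09 log units; within the scatter) from compound 3 to compound 4, 1.3-fold (0.11 log units) apart, within the scatter of two such steps. This supports carrying the change between these two cores only; two pairs at a single place do not show that it would hold on another core, nor do they exclude a small difference hidden by the scatter.

The compounds shown leave open whether a group other than the two halogens on this aromatic carbon, such as a nitrile or an amine, would shift the number beyond the scatter. As far as these compounds go, replacing the methoxy group with a longer chain also remains open.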